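Amino to ureido on compound 3

The compounds below may be only part of what the source reports. "The series", "measured", "known", "first", "only" and "open" are said of these compounds alone.

Measured so far in an ADME assay on microsomes from liver (Homo sapiens) for metabolic stability, using NADPH, with a stated time of 10 min; a higher number here means that more of the compound is left, a lower number that less of the compound is left:
- compound 1 (`NCCCCN(C[C@H]1Cc2cccnc2CN1)[C@H]1CCCc2cccnc21`) gives 96%
- compound 2 (`NCCCCN(C[C@@H]1Cc2nccnc2CN1)[C@H]1CCCc2cccnc21`) gives 87%
- compound 3 (`NC/C=C/CN(C[C@H]1Cc2ncccc2CN1)[C@H]1CCCc2cccnc21`) gives 85%

Compound 3, at 85% on this read-out, sits within the usual scatter of compound 2 at 87% on the same read-out. Compound 1 stands at 96% on the same read-out. The gap between compound 3 and compound 1 lies beyond the scatter, with compound 3 the lower of the two.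

Compound 4 (`NC(=O)NC/C=C/CN(C[C@H]1Cc2ncccc2CN1)[C@H]1CCCc2cccnc21`) has not been measured yet. Compared with compound 3, it has carbamoyl in place of hydrogen on an amine nitrogen, which turns amino to ureido (carbamoyl in place of hydrogen on an amine nitrogen).

Among the compounds with values here, no measured pair here shows a change of this kind, so the data give no direct guide to its size. In this assay no step beyond the scatter is expected, in either direction. The expected change is small, as the estimated step (a number 1 percentage points lower from compound 3 to compound 4 (within the scatter)) shows. With nothing measured to anchor it, the range is kept wide. For compound 4 the estimated value is 84% with an expected range from 68% to 96% for repeated measurements.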

Compound 4, percent of the compound remaining: 93%
Beside the measured number, compound 4's estimate is 9 percentage points below it; the range from low to high includes it.
By their numbers in this assay, from the lowest: compounds 3, 2, 4 and 1 (each within the scatter of the next, the first and the last beyond it).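

In this assay, within the data shown here, carbamoyl in place of hydrogen on an amine nitrogen gives a number 8 percentage points higher from compound 3 to compound 4 (within the scatter), the first measured step at this position. The free amino end of the chain can therefore be capped as a ureido group, adding three heavy atoms, without moving the percent remaining beyond the usual scatter. This holds for this single replacement on this one compound, and nothing available here explains why the read-out holds or gives a cause for the step.

From the compounds shown here alone, it remains open whether a smaller acetyl group or a methyl group on the same nitrogen would leave the read-out equally unmoved. Also open, going by these compounds, is whether a longer chain ending in the ureido group would behave in the same way.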